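The source may hold more compounds than are shown below. What is called first, only, known or untested is meant among the compounds shown, and "the series" means these compounds.

Measured so far in a functional assay on DU-145 cells (Homo sapiens) for inhibition, read by trypan blue exclusion, with a stated time of 96 h (a lower number here means a stronger inhibitor of growth, a higher number a weaker inhibitor of growth), are two compounds:

- Compound 1 `Cc1cc(C)cc(/C=C(\C(=O)c2ccc(Cl)cc2)S(=O)(=O)Cc2ccc(Cl)cc2)c1` gives 1000 nM 
- Compound 2 `COc1ccc(/C=C(\C(=O)c2ccc(Cl)cc2)S(=O)(=O)c2ccc(Br)cc2)cc1O` gives 10000 nM 

Compound 2 holds the higher of the two numbers, which makes it the weaker inhibitor of growth in this pair, and its gap to compound 1 lies beyond the usual scatter. Compound 3 `Cc1cc(C)cc(/C=C(\C(=O)c2ccc(Cl)cc2)S(=O)(=O)c2ccc(Br)cc2)c1` has not yet been measured and arises from compound 2 by a single change, (3,5-dimethylphenyl in place of 3-hydroxy-4-methoxyphenyl on a double-bonded chain carbon bound to a double-bonded chain carbon), namely 3,5-dimethylphenyl in place of 3-hydroxy-4-methoxyphenyl on a double-bonded chain carbon bound to a double-bonded chain carbon. Among the measured compounds shown here, no step between measured compounds isolates this change. For the measured compounds named here, the only guide is compound 1, which also carries 3,5-dimethylphenyl and gives 1000 nM in this assay, although it differs from compound 2 elsewhere as well. A fall in the number beyond the scatter is therefore expected, perhaps not spanning the whole gap between the two measured compounds. The expected move is a 4.0-fold lower number from compound 2 to compound 3 (0.60 log units; beyond the scatter), towards stronger inhibition of growth. For compound 3 the estimate is 2500 nM, with an expected range from 600 nM to 10000 nM, still to be tested.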

Compound 3, concentration for 50% growth inhibition: 10000 nM
Estimate against measurement, compound 3: 4.0-fold (0.60 log units) below; low and high end bracket the measured number.
By their numbers in this assay, from the lowest: compound 1; then compounds 2 and 3 (each within the scatter of the next).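

In this assay, 3,5-dimethylphenyl in place of 3-hydroxy-4-methoxyphenyl on a double-bonded chain carbon bound to a double-bonded chain carbon gives no change at the digits printed from compound 2 to compound 3 (within the scatter), so with 4-bromophenyl on the sulfonyl sulfur, this exchange of aryl groups leaves growth inhibition unmoved, even though the hydroxy and methoxy groups and their hydrogen-bond donor and acceptors are lost. Among the compounds shown here, with 3,5-dimethylphenyl held in place, the single change at the other site, 4-bromophenyl in place of 4-chlorobenzyl on a sulfonyl sulfur, gives a 10-fold higher number from compound 1 to compound 3 (1.00 log units; beyond the scatter), which shows that the group on the sulfonyl sulfur can shift the number while the change at the chain carbon did not. No measurement offered here accounts for either step.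

For the compounds shown here, whether the chain-carbon position would stay just as flat with 4-chlorobenzyl on the sulfonyl sulfur remains open, since the one flat step was seen only with 4-bromophenyl there. Also open, on these data alone, is how an amine or a carboxylic acid on that aryl ring, or a longer chain in place of the benzyl link on the sulfonyl sulfur, would shift the number.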